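The compounds below may be only part of what the source reports. "The series", "measured", "known", "first", "only" and "open" are said of these compounds alone.

In a functional assay on MCF7 cells (Homo sapiens) for inhibition, read by sulforhodamine B assay (a higher number here means a weaker inhibitor, a lower number a stronger inhibitor), compound 1 `O=C1C(Nc2ccccc2F)=CC(=O)c2c1nc1n2[C@H]2OC[C@@H](O)[C@H]2OC1`, which carries 2-fluorophenyl on the amine nitrogen, gives > 4000 nM as a limit, not a number. Compound 2 `O=C1C(Nc2ccc(C(F)(F)F)cc2)=CC(=O)c2c1nc1n2[C@H]2OC[C@@H](O)[C@H]2OC1` gives > 4000 nM as a limit too. Compound 3 `O=C1C(NCc2ccccc2)=CC(=O)c2c1nc1n2[C@H]2OC[C@@H](O)[C@H]2OC1`, the starting point here, also gives only a limit at > 8000 nM and so has no exact place among the three. Compound 4 `O=C1C(Nc2cccc(F)c2)=CC(=O)c2c1nc1n2[C@H]2OC[C@@H](O)[C@H]2OC1` has 3-fluorophenyl in place of benzyl on an amine nitrogen in its structure. For the measured compounds named here, the steps that bear on this, a step that the two limits leave unreadable from compound 1 to compound 3 and a step that the two limits leave unreadable from compound 2 to compound 3, have no readable size, nor does a step that the two limits leave unreadable from compound 1 to compound 2, so they give no direction. The expected step of an at least 1.6-fold lower number from compound 3 to compound 4 (0.20 log units; that floor lies within the scatter) is thus only a loose estimate. Compound 4 is expected near 5000 nM within an estimated range of 1500 nM to 12000 nM in this assay again.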

Compound 4, half-maximal inhibitory concentration: > 4000 nM
Compound 4: only a limit was reported; the forecaster's own chance of this, stated with the estimate: 70%; the middle value lies beyond the limit too.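

The steps from compound 1, compound 2 and compound 3 to compound 4 cannot be read, since each compound gives only a limit: the limit of > 4000 nM in this assay, at which 3 of the 4 values shown sit. The compounds shown leave open how strongly any of them inhibits in this assay and whether swapping the group on the amine nitrogen changes that.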